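Benzamido for acetamido at the shared core

The source may report more compounds than this note shows. Statements on the series, on what has been measured and on what is new or still open speak of the compounds shown alone.

Compound 1 `O=C(Nc1ccc(-n2ccc3c(NC(=O)c4ccccc4)ncnc32)cc1)Nc1ccc(Cl)c(C(F)(F)F)c1` and compound 2 `CC(=O)Nc1ncnc2c1ccn2-c1ccc(NC(=O)Nc2cccc(Cl)c2Cl)cc1` share the core; compound 1 carries a benzamido group and compound 2 an acetamido group, and they also differ in the aryl group at the far end. In a functional assay on A375P cells (Homo sapiens) for antiproliferative activity, read by MTT assay, with a stated time of 24 h (on this read-out lower numbers stand for stronger inhibition and higher numbers for weaker inhibition), compound 1 gives 4600 nM. Compound 2 gives > 10000 nM in this assay, which is a limit of the assay and not a number. For the measured compounds named here, this is where compound 2 stands: at the limit of > 10000 nM in this assay, at which 1 of the 2 values shown sits, so no size of step from it can be read. The unmeasured compound 3 `O=C(Nc1ccc(-n2ccc3c(NC(=O)c4ccccc4)ncnc32)cc1)Nc1cccc(Cl)c1Cl` differs from compound 2 by phenyl in place of methyl on a carbonyl carbon; the same difference, cut one bond further out, reads acetamido to benzamido. Going by the values given here, with no measured step between the two, the expectation for compound 3 in this assay rests on compound 1, which with the benzamido group gives 4600 nM. Compound 3 is therefore expected to move towards stronger inhibition, by a step of about an at least 1.6-fold lower number from compound 2 to compound 3 (0.22 log units; that floor lies within the scatter), though it may still land at the limit. The estimate for compound 3 is 6000 nM, within 2000 nM to 20000 nM.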

Compound 3, half-maximal inhibitory concentration: 4100 nM
Beside the measured number, compound 3's estimate is 1.5-fold (0.17 log units) above it; the measured number falls inside the stated range.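

For the compounds shown here, with the 2,3-dichlorophenyl group held fixed, phenyl in place of methyl on a carbonyl carbon gives the first step that can be read for this change in this assay, and that step is an at least 2.4-fold lower number from compound 2 to compound 3 (0.38 log units; beyond the scatter). Going by these compounds, the value for compound 2 is a limit of the assay and not a number, so the step gives only a floor, and its full size stays unknown: the limit of > 10000 nM in this assay, at which 1 of the 3 values shown sits. With the benzamido group held fixed, 2,3-dichlorophenyl in place of 4-chloro-3-(trifluoromethyl)phenyl on an amide-type nitrogen gives a 1.1-fold lower number from compound 1 to compound 3 (0.05 log units; within the scatter), so these two aryl groups are not told apart in this pair.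

On these data alone, what a cyclohexyl ring, a propyl chain or a pyridine ring would do on the same carbonyl carbon stays open, as does whether the aromatic ring itself counts or only the larger group. Also open, as far as these compounds go, is whether the acetamido group paired with 4-chloro-3-(trifluoromethyl)phenyl behaves as compound 2 does, and whether an amine on the benzamido ring would shift the number.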